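From butylsulfanyl to allylsulfanyl: compound 1 and compound 4

The source may report more compounds than this note shows. Statements on the series, on what has been measured and on what is new or still open speak of the compounds shown alone.

- compound 1 `CCCCSc1ncnc2ccc(I)cc12` gives 29000 nM
- compound 2 `COc1cc(-c2nnc(Sc3ncnc4c(OC)c(OC)c(OC)cc34)s2)cc(OC)c1OC` gives 31200 nM
- compound 3 `COc1cccc(Sc2ncnc3c(OC)c(OC)c(OC)cc23)c1` gives 53200 nM

All three values come from a functional assay on BGC-823 cells (Homo sapiens) for antiproliferative activity, read by MTT assay (on this read-out higher numbers stand for weaker inhibition and lower numbers for stronger inhibition), and lie within the scatter of one another, so compound 1 stands level with compound 2 and compound 3. The next compound, compound 4 `C=CCSc1ncnc2ccc(I)cc12`, keeps the core of compound 1 and changes only its chain: vinyl in place of propyl on a saturated chain carbon bound to a sulfur. This places vinyl in place of propyl on a saturated chain carbon bound to a sulfur, which can also be read as butylsulfanyl to allylsulfanyl.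

Among the measured compounds shown here, no two measured compounds differ in one place, so the data give no direct size for this change. The expectation therefore rests on compound 1 at 29000 nM as its starting point. In this assay the estimated step is a 1.1-fold lower number from compound 1 to compound 4 (0.05 log units; within the scatter) and no change beyond the scatter is expected. Compound 4 is expected at 26000 nM within an estimated range from 11000 nM to 60000 nM in this measurement.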

Compound 4, half-maximal inhibitory concentration: 33200 nM
For compound 4 the middle estimate is 1.3-fold (0.11 log units) below the measured one; measured number inside the range.
By their numbers in this assay, from the lowest: compounds 1, 2, 4 and 3 (each within the scatter of the next).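

In this assay, among the compounds shown here, vinyl in place of propyl gives a 1.1-fold higher number from compound 1 to compound 4 (0.06 log units; within the scatter), the first direct comparison of two compounds that differ in one place. On a saturated chain carbon bound to a sulfur, then, the double bond of the allylsulfanyl chain brings no change beyond the scatter, and on the core of compound 1 butylsulfanyl and allylsulfanyl stand level on this read-out. No independent measurement is available to explain this outcome.

From the compounds shown here alone, whether an amine or a carboxylic acid on this chain, or a longer chain such as octyl, would move the number beyond the scatter remains open. Also open, going by these compounds, is whether vinyl in place of propyl would stay this quiet on a core other than that of compound 1.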